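The source may report more compounds than this note shows. Statements on the series, on what has been measured and on what is new or still open speak of the compounds shown alone.

Compound 1 `COCc1nc2nc(C)cc(Nc3ccc(S(F)(F)(F)(F)F)cc3)n2n1` is a fused two-ring core carrying a methoxymethyl group and an aniline that bears a pentafluorosulfanyl group. In an in vitro ADME assay on microsomes from liver (Homo sapiens) for metabolic stability (on this read-out higher numbers stand for fast clearance and lower numbers for slow clearance), compound 1 gives 5.6 mL.min-1.g-1, the lowest of the two numbers recorded here. Compound 2 `Cc1cc(Nc2cccc(Cl)c2)n2nc(C(C)(F)F)nc2n1`, which carries a 1,1-difluoroethyl group and a chlorine-bearing aniline, gives 44.4 mL.min-1.g-1 in this assay, a gap from compound 1 that lies beyond the usual scatter. One value in this assay is not a number at all but a limit: the limit of < 5 mL.min-1.g-1 in this assay, at which 1 of the 3 values shown sits. That value belongs to compound 3 `Cc1cc(Nc2ccc(C(F)(F)F)cc2)n2nc(CCO)nc2n1`, which gives < 5 mL.min-1.g-1 in this assay.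

Compound 4 `Cc1cc(Nc2ccc(S(F)(F)(F)(F)F)cc2)n2nc(C(C)(F)F)nc2n1` has not yet been measured. It differs from compound 1 in one place: 1,1-difluoroethyl in place of methoxymethyl on an aromatic carbon. Among the measured compounds shown here, no single-change step between measured compounds covers this swap; compound 2 shares the 1,1-difluoroethyl group but also differs at the aniline, so its value can only be noted, not used as a step. In this assay compound 4 is expected to give 14 mL.min-1.g-1, within a range from 6 mL.min-1.g-1 to 40 mL.min-1.g-1. That estimate means an expected step of a 2.5-fold higher number from compound 1 to compound 4 (0.40 log units; beyond the scatter), upward and of a size that may edge beyond the scatter.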

Compound 4, intrinsic clearance in microsomes: < 5 mL.min-1.g-1
Compound 4 was reported as a limit; the forecaster's own chance of this, stated with the estimate: 10%; at least 2.8-fold (0.44 log units) between middle value and limit.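

With compound 4 there is now a single-change step at this position, on an aromatic carbon of the five-membered aromatic ring: in this assay, putting 1,1-difluoroethyl in place of methoxymethyl gives an at least 1.1-fold lower number from compound 1 to compound 4 (0.04 log units; that floor lies within the scatter). Compound 4 gives < 5 mL.min-1.g-1, which is a limit of the assay and not a number. The step therefore shows that, with the pentafluorosulfanyl aniline kept in place, methoxymethyl can leave this position without the reading moving up, although its true size stays hidden, and compound 4 adds to the values that cannot be told apart at the bottom of the scale: the limit of < 5 mL.min-1.g-1 in this assay, at which 2 of the 4 values shown sit.

On these data alone, whether compound 1 and compound 4 truly differ in clearance remains open, as the step's floor lies within the usual scatter and compound 4 has no exact number. Also open, as far as these compounds go, is whether the reading would stay this low with an amine, a carboxylic acid or a longer alkyl chain such as butyl at this position on the shared core.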